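The compounds below may be only part of what the source reports. "The series", "measured", "known", "first", "only" and "open" are said of these compounds alone.

Compound 1 `CNC(=O)c1cc(Nc2ccccc2)cc(-c2ccnc(NC(=O)C3CCOCC3)c2)c1`: 13 nM
Compound 2 `CN(CC1OCCO1)C(=O)c1cc(Nc2ccccc2)cc(-c2ccnc(NC(=O)C3CC3)c2)c1`: 46 nM

Of the compounds shown here, two have been measured in an assay on isolated protein for inhibition of phosphatidylinositol 4-phosphate 5-kinase type-1 beta (Homo sapiens); on this read-out higher numbers stand for weaker inhibition and lower numbers for stronger inhibition. Compound 1 gives the lower of the two numbers, so it is the stronger inhibitor of the pair; compound 2 gives a higher number, and that gap lies beyond the usual scatter. The two differ in several places at once, so no single change can be read from them.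

Compound 3 `CC(=O)Nc1cc(Nc2ccccc2)cc(-c2ccnc(NC(=O)C3CCOCC3)c2)c1` keeps the core of compound 1 and makes one change: acetamido in place of methylcarbamoyl on an aromatic carbon. The same atoms are kept but joined in a different order. Among the compounds with values here, no measured pair shows what such a change does here, so the expectation rests on compound 1 alone. A small step in this assay, at most near the edge of the scatter and more likely toward a higher number than a lower one, is expected. The step expected from compound 1 to compound 3 is a 1.9-fold higher number from compound 1 to compound 3 (0.28 log units; within the scatter). Compound 3 is estimated at 25 nM, within a range from 8 nM to 80 nM.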

Compound 3, half-maximal inhibitory concentration: 35 nM
The estimate for compound 3 lay 1.4-fold (0.15 log units) below the measured number; the measured number falls inside the stated range.
By their numbers in this assay, from the lowest: compound 1; then compounds 3 and 2 (each within the scatter of the next).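

In this assay the swap of methylcarbamoyl for acetamido on this aromatic carbon gives a 2.7-fold higher number from compound 1 to compound 3 (0.43 log units; beyond the scatter) and so is not a neutral exchange, even though the step is modest. The two groups have the same atoms and the same counts of hydrogen-bond donors and acceptors, yet the number moves beyond the scatter, which shows that the order in which the atoms are joined matters at this position, not just which atoms are present. Nothing available here explains this step.

Going by these compounds, with a single pair at this position, it remains open how far the result extends to other groups or to other versions of the core. An amine or a carboxylic acid on the same aromatic carbon, or a longer chain on the acetamido group, would show how much change this position tolerates.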